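The compounds below may be only part of what the source reports. "The series", "measured", "known", "first", "only" and "open" are said of these compounds alone.

Working notes on the series, as read so far in a physicochemical assay for lipophilicity; on this read-out lower numbers stand for lower lipophilicity and higher numbers for higher lipophilicity. Compound 1 `CCOc1ccccc1C1=NC(c2ccccc2)CO1` gives 4.22 and compound 2 `Clc1ccc(C2=NC(c3ccccc3)CO2)cc1` gives 4.48 in this read-out, so the two lie within the scatter of each other. Compound 3 `FC(F)(F)c1ccccc1-c1ncco1` gives 2.15 and stands apart, well beyond the scatter under compound 1. Compound 1 therefore sits at the upper end of the three numbers together with compound 2.

The next compound to be read is compound 4 `Ic1ccccc1C1=NC(c2ccccc2)CO1`, which keeps the core of compound 1 and changes one substituent (iodo in place of ethoxy on an aromatic carbon) with iodo in place of ethoxy on an aromatic carbon. Among the compounds with values here, no two measured compounds differ in one place only, so the series offers no measured step to calibrate this change. The expectation rests on the structural change alone, with compound 1 at 4.22 as the anchor. A modest rise in this assay is expected, and it may not clear the scatter by much. The estimated step is a number 0.43 log units higher from compound 1 to compound 4 (beyond the scatter). For compound 4 the expected value is 4.65 with an estimated range from 4.2 to 5.1 in this read-out.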

Compound 4, partition coefficient: 3.86
For compound 4 the middle estimate is 0.79 log units above the measured one; measured number outside the range, below it.
By their numbers in this assay, from the lowest: compound 3; then compound 4; then compounds 1 and 2 (each within the scatter of the next).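

The series now holds its first measured step in one place: iodo in place of ethoxy on an aromatic carbon, ortho to a large group, gives a number 0.36 log units lower from compound 1 to compound 4 (beyond the scatter) in this assay. Within the data shown here, the exchange removes ethoxy, with 3 heavy atoms and 1 hydrogen-bond acceptor, and brings in iodo, with 1 heavy atom and 0 hydrogen-bond acceptors; at this position on the shared core, the read-out moves down with it, a direction the earlier compounds could not show, as no two of them differed in one place only. No measurement at hand accounts for the direction or the size of this step.

This is a single pair, so it leaves open whether the same exchange would run the same way elsewhere on the six-membered aromatic ring or on a different core. Also open, as far as these compounds go, is how an amine, a carboxylic acid or a longer chain such as butoxy, carried at this same position, would stand against ethoxy and iodo in this assay.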